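The compounds below may be only part of what the source reports. "The series", "measured", "known", "first", "only" and "open" are said of these compounds alone.

Compound 1 `Cc1noc(C)c1-c1cnc(N)c(Oc2ccc(C(=O)Nc3ccccc3Cl)cc2)n1`, compound 2 `Cc1noc(C)c1-c1cnc(N)c(Oc2ccc(C(=O)Nc3ccc(Cl)cn3)cc2)n1` and compound 3 `Cn1cc(-c2cnc(N)c(Oc3ccc(C(=O)Nc4ccccc4Cl)cc3)n2)cn1` share one core and are distinguished only at two positions. In a functional assay on HepG2 cells (Homo sapiens) for inhibition, read by MTT assay, with a stated time of 72 h (on this read-out lower numbers stand for stronger inhibition and higher numbers for weaker inhibition), compound 3 gives 66900 nM. That is the higher of the two numbers reported; the nearest is compound 2, which in this assay gives 35600 nM, a gap that lies within the scatter. Compound 1 in this assay returns no number but a limit, > 100000 nM, namely (the limit of > 100000 nM in this assay, at which 1 of the 3 values shown sits).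

The unmeasured compound 4 `Cn1cc(-c2cnc(N)c(Oc3ccc(C(=O)Nc4ncccc4Cl)cc3)n2)cn1` differs from compound 3 by 3-chloropyridin-2-yl in place of 2-chlorophenyl on an amide-type nitrogen. One measured step speaks to an exchange of this kind on the amide-type nitrogen: an at least 2.8-fold lower number from compound 1 to compound 2 (0.44 log units; beyond the scatter). Because compound 1 sits at a limit, only a floor for that step is known. The other step, an at least 1.4-fold lower number from compound 1 to compound 3 (0.17 log units; that floor lies within the scatter), concerns the aromatic carbon and says nothing about the amide end. Within the data shown here, the pyridinyl entering compound 4 carries its chlorine at a different ring position than the one in compound 2, so the analogy is loose. A modest lowering is therefore expected, a 2.2-fold lower number from compound 3 to compound 4 (0.35 log units; beyond the scatter), and compound 4 is estimated at 30000 nM, within a range from 10000 nM to 100000 nM.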

Compound 4, half-maximal inhibitory concentration: 21700 nM
Estimate against measurement, compound 4: 1.4-fold (0.14 log units) above, and the stated range covers the measured number.
By their numbers in this assay, from the lowest: compounds 4, 2 and 3 (each within the scatter of the next, the first and the last beyond it). At a limit, above all of these: compound 1.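

In this assay, the exchange of 2-chlorophenyl for 3-chloropyridin-2-yl on the amide-type nitrogen now has a size read between two real numbers, a 3.1-fold lower number from compound 3 to compound 4 (0.49 log units; beyond the scatter). Together with an at least 2.8-fold lower number from compound 1 to compound 2 (0.44 log units; beyond the scatter), it shows a lower number in both pairs where a chloropyridinyl group replaces 2-chlorophenyl at this position, with either of the two groups on the aromatic carbon and with the chlorine at either of the two ring positions shown, and no compound shown goes against this. The earlier step gave only a floor, since compound 1 stands at a limit and not at a number: the limit of > 100000 nM in this assay, at which 1 of the 4 values shown sits.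

The compounds shown cannot separate the contribution of the ring nitrogen from that of the chlorine, and a plain pyridin-2-yl or a 3-fluoropyridin-2-yl on the same amide-type nitrogen would speak to that. Among these compounds, a 5-chloropyridin-2-yl group paired with 1-methyl-1H-pyrazol-4-yl would also set the two chlorine placements against each other on one shared core, which no pair here allows.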